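Replacing the vinylsulfonamide of compound 1 with a ring

A few compounds are considered here, and "the series" means these few. Any claim that something is new, unique, unknown or untested is made for them only; others in the source may bear on it.

Measured compounds:
compound 1, `C=CS(=O)(=O)NC/C=C/c1cc(OC)cc(O)c1C(=O)OCC1CCCCC1`, 56.4%
compound 2, `C=CS(=O)(=O)NC/C=C/c1cc(OC)cc(O)c1C(=O)OCc1ccc(Br)cc1`, 61%
compound 3, `C=CS(=O)(=O)NC/C=C/c1cc(OC)cc(O)c1C(=O)OCc1ccc(F)cc1`, 70.5%

The three compounds were tested in a functional assay on MV4-11 cells (Homo sapiens) for inhibition, read by luminescence, with a stated time of 72 h, tested at 5 uM; on this read-out lower numbers stand for less inhibition of growth and higher numbers for more inhibition of growth at the one concentration tested. Compound 1 sits at the low end of the three numbers: a number 4.6 percentage points higher from compound 1 to compound 2 (within the scatter), while a number 14.1 percentage points higher from compound 1 to compound 3 (beyond the scatter). Between the two aryl esters, a number 9.5 percentage points higher from compound 2 to compound 3 (within the scatter).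

Compound 4, `COc1cc(O)c(C(=O)OCC2CCCCC2)c(/C=C/CN2C(=O)C=CC2=O)c1`, keeps the ester of compound 1 and changes the other arm of the shared core: a group of 7 heavy atoms (4 carbon, 1 nitrogen, 2 oxygen; one five-membered non-aromatic ring with 1 hetero atom) in place of a group of 6 heavy atoms (2 carbon, 1 nitrogen, 2 oxygen, 1 sulfur; no ring), on a saturated chain carbon bound to a double-bonded chain carbon. None of the three measured steps touches this part of the molecule; all of them vary the group on the saturated chain carbon bound to the oxygen of the ester, and the largest of them was only modest. Going by the values given here, there is therefore no measured step that bears on the change from compound 1 to compound 4, and the expectation rests on compound 1 alone. Without a precedent, compound 4 is expected to stay near compound 1, with a number 0.6 percentage points higher from compound 1 to compound 4 (within the scatter) and no shift beyond the scatter foreseen. On these data alone, compound 4 is thus estimated at 57%, within a range from 35% to 80% in this assay, the width reflecting that the change is untested.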

Compound 4, percent growth inhibition at one concentration: 99.8%
For compound 4 the middle estimate is 42.8 percentage points below the measured one, outside the stated range (above it).
By their numbers in this assay, from the lowest: compounds 1, 2 and 3 (each within the scatter of the next, the first and the last beyond it); then compound 4.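

In this assay, the arm on the saturated chain carbon bound to a double-bonded chain carbon turns out to be a strong lever on growth inhibition: with the ester held constant, exchanging the (vinylsulfonyl)amino group for the group bearing a five-membered non-aromatic ring gives a number 43.4 percentage points higher from compound 1 to compound 4 (beyond the scatter). The earlier compounds varied only the ester, and the largest step among them was a number 14.1 percentage points higher from compound 1 to compound 3 (beyond the scatter), so they gave no sign that the other arm could move this read-out so far, and the new step is the only large one shown. Going by these compounds alone, nothing available here explains the gain, and the step itself shows only that the exchange as a whole raises the number.

On these data alone, what remains open is which feature of the entering group carries the step, since the ring arrives together with the loss of the hydrogen-bond donor, and an acrylamide on the same chain carbon would help to separate these features. As far as these compounds go, it is also open whether the 4-fluorophenyl or 4-bromophenyl esters behave alongside the ring as they do alongside the (vinylsulfonyl)amino group, and with compound 4 at 99.8% at the one concentration tested, any such comparison would need a lower concentration or a full dose-response read-out.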